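From hydroxypyrrolidine to hydroxypiperidine on the carbonyl

A few compounds are considered here, and "the series" means these few. Any claim that something is new, unique, unknown or untested is made for them only; others in the source may bear on it.

Of the compounds shown here, two have been measured so far in an ADME assay on microsomes from liver (Homo sapiens) for metabolic stability, read by LC-MS, using NADPH, with a stated time of 30 min, tested at 0.1 uM, in the presence of a further agent that is not named here (on this read-out higher numbers stand for a more stable compound and lower numbers for a less stable compound), to date.
Compound 1 `NC(=O)c1ccc(-c2cnc(N)c(-c3ccc(C(F)(F)F)cc3)n2)cc1` gives > 90% as a limit.
Compound 2 `Nc1ncc(-c2ccc(C(=O)N3CC[C@H](O)C3)cc2)nc1-c1ccc(C(F)(F)F)cc1` gives > 90% as a limit.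

Compound 2 thus has no exact number, only > 90% as a limit. Taken together, the measurements show the limit of > 90% in this assay, at which 2 of the 2 values shown sit, and nothing finer. Within the data shown here, the one measured step that bears on the next change is a step that the two limits leave unreadable from compound 1 to compound 2 and offers no size to carry forward. Compound 3 `Nc1ncc(-c2ccc(C(=O)N3CCC(O)CC3)cc2)nc1-c1ccc(C(F)(F)F)cc1` carries 4-hydroxypiperidin-1-yl in place of 3-hydroxypyrrolidin-1-yl on a carbonyl carbon, a change counted as 4-hydroxypiperidin-1-yl in place of 3-hydroxypyrrolidin-1-yl on a carbonyl carbon in full. Resting on compound 2 with > 90% as a limit, no step beyond the usual scatter is expected in this assay in either direction. The estimated step is a step that the limit leaves unreadable from compound 2 to compound 3 in size. For compound 3 the estimate is 91% within an expected range from 78% to 100% in this read-out.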

Compound 3, percent of the compound remaining: > 90%
Compound 3 ended at the assay's limit (the forecaster's own chance of this, stated with the estimate: 60%); the middle value does not contradict the limit.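

No step can be read among compound 1, compound 2 and compound 3 in this assay, because all three rest on one limit: the limit of > 90% in this assay, at which 3 of the 3 values shown sit.

The compounds shown leave open whether 4-hydroxypiperidin-1-yl in place of 3-hydroxypyrrolidin-1-yl changes this read-out at all, and by how much.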